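Replacing the difluoroethyl group with a heteroaromatic ring

The source may report more compounds than this note shows. Statements on the series, on what has been measured and on what is new or still open speak of the compounds shown alone.

Of the compounds shown here, two have been measured in a functional assay on isolated protein for inhibition of Glucose-dependent insulinotropic receptor (Rattus norvegicus), read by HTRF and cAMP accumulation; a lower number here means that less compound is needed, a higher number that more compound is needed for the effect. Compound 1 `Cc1nc(S(C)(=O)=O)ccc1Oc1ncnc(OC2CCN(C(=O)SC3CC3)CC2)c1F` gives 126 nM, and compound 2 `Cc1nc(S(C)(=O)=O)ccc1Oc1ncnc(OC2CCN(C(=O)C(C)(F)F)CC2)c1F` gives 239 nM. Compound 2 has the highest of the two numbers, but its nearest neighbour is compound 1, and the step of a 1.9-fold higher number from compound 1 to compound 2 (0.28 log units; within the scatter) lies within the scatter, so the two cannot be told apart.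

Compound 3 `Cc1nc(S(C)(=O)=O)ccc1Oc1ncnc(OC2CCN(C(=O)c3noc(C(C)(C)F)n3)CC2)c1F` is not yet measured. It differs from compound 2 in one place: a group of 9 heavy atoms (5 carbon, 2 nitrogen, 1 oxygen, 1 fluorine; one five-membered aromatic ring with 3 hetero atoms) in place of a group of 4 heavy atoms (2 carbon, 2 fluorine; no ring), on a carbonyl carbon. Going by the values given here, the only measured step touches the same carbonyl carbon, where a 1.9-fold higher number from compound 1 to compound 2 (0.28 log units; within the scatter) changed little. That single step gives no ground to expect a large move in either direction; the entering group, however, is larger and differs more from its predecessor than the earlier swap did, so the range stays wide. For compound 3 the expected step is a 1.5-fold lower number from compound 2 to compound 3 (0.17 log units; within the scatter), giving an estimate of 160 nM with a range from 40 nM to 650 nM.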

Compound 3, half-maximal effective concentration: 103 nM
Compound 3: the middle estimate sits 1.6-fold (0.19 log units) above what was measured; the range from low to high includes it.
By their numbers in this assay, from the lowest: compounds 3, 1 and 2 (each within the scatter of the next, the first and the last beyond it).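

Going by these compounds alone, on the carbonyl carbon, this assay tolerates a far bigger group than the earlier compounds showed: a five-membered aromatic ring unit of 9 heavy atoms, with 3 hydrogen-bond acceptors, replaces the 1,1-difluoroethyl group of 4 heavy atoms and none, and the result is a 2.3-fold lower number from compound 2 to compound 3 (0.37 log units; beyond the scatter), a modest move but the first at this position beyond the scatter. The group on compound 1 is also very different from the new one, yet the swap gives a 1.2-fold lower number from compound 1 to compound 3 (0.09 log units; within the scatter), so compound 1 and compound 3 cannot be told apart. No measurement here accounts for the change in number.

From the compounds shown here alone, it remains open whether the aromatic ring itself or the fluorine it carries matters for the move from compound 2 to compound 3. A phenyl ring or a simple amine on the same carbonyl carbon would also be untested ground in these compounds.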